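The compounds below may be only part of what the source reports. "The series", "measured", "known", "first", "only" and "open" are said of these compounds alone.

Three compounds of the series have so far been run in an ADME assay on a cell-free system (plasma, Homo sapiens), read by HPLC, with a stated time of 120 min, at 37 degrees C; a lower number here means that less of the compound is left, a higher number that more of the compound is left. Compound 1 `CC(OC(=O)C(C)C)OC(=O)N1CCN(C(=O)c2nc(Nc3cc(C4CC4)[nH]n3)c3cc(Cl)ccc3n2)C[C@H]1C` gives 17.4%, compound 2 `CC(C)OC(=O)N1CCN(C(=O)c2nc(Nc3cc(C4CC4)[nH]n3)c3cc(Cl)ccc3n2)C[C@H]1C` gives 78.5%, and compound 3 `CC(C)COC(=O)N1CCN(C(=O)c2nc(Nc3cc(C4CC4)[nH]n3)c3cc(Cl)ccc3n2)C[C@H]1C` gives 73.7%. Compound 3 thus stands second highest of the three: nearest to it is compound 2, with a number 4.8 percentage points lower from compound 2 to compound 3 (within the scatter), and furthest is compound 1, with a number 56.3 percentage points higher from compound 1 to compound 3 (beyond the scatter). Compound 4 `CC(C)C(=O)OCOC(=O)N1CCN(C(=O)c2nc(Nc3cc(C4CC4)[nH]n3)c3cc(Cl)ccc3n2)C[C@H]1C` remains unmeasured. Its change from compound 3 is (isopropylcarbonyl)oxy in place of isopropyl on a saturated chain carbon bound to an oxygen next to a carbonyl group. The measured steps that bear on it are a number 61.1 percentage points higher from compound 1 to compound 2 (beyond the scatter) and a number 56.3 percentage points higher from compound 1 to compound 3 (beyond the scatter), both of which remove the (isopropylcarbonyl)oxy grouping that compound 4 takes on. Read in reverse, a large drop in this assay is therefore expected, a number 53.7 percentage points lower from compound 3 to compound 4 (beyond the scatter). Compound 4 is estimated at 20%, within a range of 8% to 40%.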

Compound 4, percent of the compound remaining: 6.1%
Compound 4: the middle estimate sits 13.9 percentage points above what was measured; measured number below the stated range.
By their numbers in this assay, from the lowest: compound 4; then compound 1; then compounds 3 and 2 (each within the scatter of the next).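

Adding (isopropylcarbonyl)oxy in place of isopropyl on a saturated chain carbon bound to an oxygen next to a carbonyl group gives a number 67.6 percentage points lower from compound 3 to compound 4 (beyond the scatter), and exchanging the isopropyl on that oxygen for ((isopropylcarbonyl)oxy)methyl gives a number 72.4 percentage points lower from compound 2 to compound 4 (beyond the scatter). The earlier compounds shown here did not show that the methyl also counts in this assay: hydrogen in its place gives a number 11.3 percentage points lower from compound 1 to compound 4 (beyond the scatter). No evidence here accounts for these steps. Open, as far as these compounds go, is whether a longer chain or an amine in place of the isopropyl in (isopropylcarbonyl)oxy would shift the number.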